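The source may hold more compounds than are shown below. What is called first, only, known or untested is meant among the compounds shown, and "the series" means these compounds.

Measured so far in an assay on isolated protein for inhibition of advanced glycosylation end product-specific receptor (Homo sapiens), read by FRET, with stated times of 30 min and 1 h, tested at 4 uM; on this read-out higher numbers stand for more inhibition at the one concentration tested (going by the name of the read-out) and lower numbers for less inhibition:
Compound 1 `CCN1CCC(COc2ccc(-c3nc4ccc(Oc5ccc(Cl)cc5)cc4o3)cc2)CC1` gives 2.1%.
Compound 2 `CN(C)CCCOc1ccc(-c2nc3ccc(Oc4ccc(Cl)cc4)cc3o2)cc1` gives 4.9%.
Compound 3 `N[C@H]1CCN(CCCOc2ccc(-c3nc4ccc(Oc5ccc(Cl)cc5)cc4o3)cc2)C1` gives 29.9%.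

Compound 3 stands highest of the three numbers: a number 27.8 percentage points higher from compound 1 to compound 3 (beyond the scatter) and a number 25 percentage points higher from compound 2 to compound 3 (beyond the scatter), both beyond the scatter, whereas a number 2.8 percentage points higher from compound 1 to compound 2 (within the scatter). Compound 4 `Clc1ccc(Oc2ccc3nc(-c4ccc(OCCCN5CCCCC5)cc4)oc3c2)cc1` differs from compound 3 in one place: piperidin-1-yl in place of 3-aminopyrrolidin-1-yl on a saturated chain carbon, three bonds along the chain from an oxygen on an aromatic ring. Among the measured compounds shown here, the steps that bear on this change are the two that lead to compound 3, since compounds 1 and 2, which also lack the 3-aminopyrrolidin-1-yl group, both sit far lower in this assay. Removing that group is therefore expected to undo most of the gain, a step of a number 21.9 percentage points lower from compound 3 to compound 4 (beyond the scatter) downward beyond the scatter. Compound 4 is estimated at 8%, with a range from 0% to 22%.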

Compound 4, a percentage reported as inhibition, at one concentration (the size of the read-out at that concentration, not a potency): 2.2%
Compound 4: middle estimate off by 5.8 percentage points, on the high side, and the stated range covers the measured number.
By their numbers in this assay, from the lowest: compounds 1, 4 and 2 (each within the scatter of the next); then compound 3.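

In this assay, a ring alone at this place on the chain does not hold the number up: with piperidin-1-yl, which has no hydrogen-bond donor, in place of 3-aminopyrrolidin-1-yl, there is a number 27.7 percentage points lower from compound 3 to compound 4 (beyond the scatter). Compound 4 cannot be told apart from the two other compounds that lack the 3-aminopyrrolidin-1-yl group, with a number 2.7 percentage points lower from compound 2 to compound 4 (within the scatter) and a number 0.1 percentage points higher from compound 1 to compound 4 (within the scatter). No measurement here explains the drop.

Still open, from the compounds shown here alone, is whether the gain belongs to the amino group or to the five-membered ring. Plain pyrrolidin-1-yl and 4-aminopiperidin-1-yl at this place would separate the two.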